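This account rests on a few compounds, and the source may have more. Where it says the series, first, only, none or still open, it means among the compounds named here.

For the measured compounds named here, in a functional assay on KG-1 cells (Homo sapiens) for cytotoxicity, read by luminescence and CellTiter-Glo, with a stated time of 3 days (on this read-out higher numbers stand for weaker inhibition and lower numbers for stronger inhibition), three compounds have numbers so far. Compound 1 (`N#Cc1ccc(NC(=O)c2cc(Cl)ccc2O)c(Cl)c1`) gives 860 nM and compound 3 (`O=C(Nc1ccc(OC(F)(F)F)c(Cl)c1)c1ccc(C(F)(F)F)cc1O`) gives 640 nM in this assay, two values within the scatter of each other. Compound 2 (`Cc1ccc(C(=O)Nc2ccc(C#N)cc2)c(O)c1`) gives 2560 nM and so stands beyond the scatter from compound 1, with the higher number and thus weaker inhibition.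

The next compound to be measured is compound 4 (`N#Cc1ccc(NC(=O)c2cc(Cl)ccc2O)cc1`). It has hydrogen in place of chloro on an aromatic carbon of compound 1, at a place ortho to a large group and meta to a cyano group (hydrogen in place of chloro on an aromatic carbon). Going by the values given here, no measured pair shows this change alone, so the data offer only indirect guidance. Compound 2 at 2560 nM also has hydrogen on that carbon and also carries the cyano group, but it differs from compound 4 elsewhere as well.

On that slender basis, the estimated step of a 2.1-fold higher number from compound 1 to compound 4 (0.32 log units; beyond the scatter) is expected in this assay as a rise in the number, of a size near the edge of the scatter. For compound 4 the expected value is 1800 nM within an estimated range of 750 nM to 4300 nM in this assay.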

Compound 4, half-maximal inhibitory concentration: 1860 nM
Estimate against measurement, compound 4: 1.0-fold (0.01 log units) below; low and high end bracket the measured number.
By their numbers in this assay, from the lowest: compounds 3 and 1 (each within the scatter of the next); then compounds 4 and 2 (each within the scatter of the next).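

In this assay, the chloro on the aromatic carbon ortho to a large group and meta to a cyano group now has a direct reading, since hydrogen in place of chloro gives a 2.2-fold higher number from compound 1 to compound 4 (0.34 log units; beyond the scatter) and nothing else in the structure changes. For the compounds shown here, this is the first pair that isolates this position, and it shows that the chloro is not neutral here: its loss moves the number up, towards weaker inhibition, by a modest step. Nothing measured here accounts for the step, and its cause remains unknown.

The compounds shown leave open how a fluoro group, a methoxy group or an amine on this same carbon would read, as chloro and hydrogen are the only two groups compared there. Going by these compounds alone, they also leave open whether the same exchange would give a step of similar size and direction on another core, such as that of compound 3, as this one pair is the only reading of the change so far.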